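The source may hold more compounds than are shown below. What is called first, only, known or untested is meant among the compounds shown, and "the series" means these compounds.

Among the compounds with values here, compound 2 `CC(C)c1ccccc1OS(=O)(=O)c1ccc(NC(=O)CCCl)cc1` is one of two compounds measured in a functional assay on MCF7 cells (Homo sapiens) for antiproliferative activity, read by sulforhodamine B assay, with a stated time of 48 h (a higher number here means a weaker inhibitor, a lower number a stronger inhibitor), and in this assay compound 2 gives 9000 nM. Within the data shown here, its only neighbour, compound 1 `CCCCCC(=O)Nc1ccc(S(=O)(=O)Oc2ccccc2C(C)C)cc1`, gives 5300 nM, so the two numbers sit within the scatter of each other. Among the measured compounds shown here, the single measured step, a 1.7-fold higher number from compound 1 to compound 2 (0.23 log units; within the scatter), changed nothing beyond that scatter. Compound 3 `CC(C)c1ccccc1OS(=O)(=O)c1ccc(NC(=O)CCCCl)cc1` differs from compound 2 by chloromethyl in place of chloro on a saturated chain carbon, two bonds along the chain from a carbonyl carbon. For the measured compounds named here, with that earlier step as the only guide, the expected step of a 1.1-fold lower number from compound 2 to compound 3 (0.02 log units; within the scatter) is small. Compound 3 is therefore estimated at 8500 nM, with a range from 3500 nM to 20000 nM.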

Compound 3, half-maximal inhibitory concentration: 5200 nM
Compound 3: middle estimate off by 1.6-fold (0.21 log units), on the high side; the range from low to high includes it.
By their numbers in this assay, from the lowest: compounds 3, 1 and 2 (each within the scatter of the next).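

With chloromethyl in place of chloro on a saturated chain carbon, two bonds along the chain from a carbonyl carbon, this assay shows a 1.7-fold lower number from compound 2 to compound 3 (0.24 log units; within the scatter) and so no change beyond the scatter at this position. Chloro in place of ethyl, three bonds along the chain from a carbonyl carbon, gives a 1.0-fold lower number from compound 1 to compound 3 (0.01 log units; within the scatter) and also stays within the scatter. No available evidence bears on these results. The compounds shown leave open whether an amine, a carboxylic acid or a longer chain at this position would move the number beyond the scatter.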